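Compound 3 Gives Up One Hydroxy Group

A few compounds are considered here, and "the series" means these few. Any claim that something is new, unique, unknown or untested is made for them only; others in the source may bear on it.

- Compound 1 `CCOC(=O)C1=C(C)NC(=S)NC1c1cccc(OC)c1` gives 1.3 ug/mL
- Compound 2 `CCOC(=O)C1=C(C)NC(=S)NC1c1ccc(SC)cc1` gives 8.5 ug/mL
- Compound 3 `CCOC(=O)C1=C(C)NC(=O)NC1c1ccc(O)c(O)c1` gives 1.6 ug/mL

In a functional assay on OVCAR-3 cells (Homo sapiens) for inhibition, read by sulforhodamine B assay, with a stated time of 48 h (on this read-out higher numbers stand for weaker inhibition of growth and lower numbers for stronger inhibition of growth), compound 3 gives 1.6 ug/mL and stands within the usual scatter of compound 1 with 1.3 ug/mL on this read-out. Compound 2 with 8.5 ug/mL lies beyond the scatter from compound 3, on the side of weaker inhibition of growth.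

The next compound is compound 4 `CCOC(=O)C1=C(C)NC(=O)NC1c1ccc(O)cc1` and it is still to be measured in this assay. Its structure departs from that of compound 3 in one place only: hydrogen in place of hydroxy on an aromatic carbon. Among the compounds with values here, no two measured compounds differ from each other in a single place, so the data offer no direct guide to this change. The measured values reach only as far as compound 2 with 8.5 ug/mL in this small set, so a modest shift is expected rather than a large one. The expected step is a 1.9-fold higher number from compound 3 to compound 4 (0.27 log units; within the scatter) in the direction of weaker inhibition of growth, and it may not clear the scatter. For compound 4 the estimated value is 3 ug/mL with an expected range from 0.9 ug/mL to 10 ug/mL in this assay.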

Compound 4, concentration for 50% growth inhibition: 27.3 ug/mL
Estimate against measurement, compound 4: 9.1-fold (0.96 log units) below; measured number above the stated range.
By their numbers in this assay, from the lowest: compounds 1 and 3 (each within the scatter of the next); then compound 2; then compound 4.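

In this assay, the hydroxy group that sits ortho to a hydroxy group and meta to a large group cannot be exchanged for hydrogen without cost: the change gives a 17-fold higher number from compound 3 to compound 4 (1.23 log units; beyond the scatter), a large step toward weaker inhibition of growth. Within the data shown here, this is the first comparison in the set between two compounds that differ in one place, and it shows that a single oxygen-bearing group on the aromatic ring carries much of the growth inhibition seen with compound 3. Nothing at hand explains why the loss of this one heavy atom weighs so heavily.

The compounds shown leave open whether the hydroxy group itself is needed at this place or whether another group, such as a methoxy group, an amine or a fluorine atom, could hold the inhibition of growth seen with compound 3. They also leave open what the hydroxy group that remains in compound 4 contributes, and whether the same exchange would cost as much on a core bearing a thiocarbonyl in place of the carbonyl.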